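Pyrazin-2-yl to pyrimidin-2-yl exchange: working notes

A few compounds are considered here, and "the series" means these few. Any claim that something is new, unique, unknown or untested is made for them only; others in the source may bear on it.

Values so far in a functional assay on L5178Y cells (Mus musculus) for antiproliferative activity, read by MTT assay (on this read-out higher numbers stand for weaker inhibition and lower numbers for stronger inhibition), are:
- compound 1 `CC(=O)c1ccc(OCCCCN2CCN(c3ncccn3)CC2)cc1` gives 31.6 nM
- compound 2 `CC(C)(C)c1ccc(OCCCCN2CCN(c3ncccn3)CC2)cc1` gives 11.3 nM
- compound 3 `CCC(C)(C)c1ccc(OCCCCN2CCN(c3cnccn3)CC2)cc1` gives 9.56 nM

Compound 3 stands at the low end of the three numbers, within the scatter of compound 2 and lower than compound 1 by more than the scatter.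

Compound 4 `CCC(C)(C)c1ccc(OCCCCN2CCN(c3ncccn3)CC2)cc1` has pyrimidin-2-yl in place of pyrazin-2-yl on an amine nitrogen in a ring. Going by the values given here, no measured step isolates this exchange. Among the compounds with values here, the only measured step (a 2.8-fold lower number from compound 1 to compound 2 (0.45 log units; beyond the scatter)) is tert-butyl in place of acetyl on an aromatic carbon, a modest change elsewhere that says nothing direct about the exchange. Compound 2 also carries pyrimidin-2-yl, and its value (11.3 nM) sits within the scatter of compound 3. No step beyond the scatter is therefore expected in this assay, and no direction can be favoured. The expected step is small (a 1.1-fold higher number from compound 3 to compound 4 (0.04 log units; within the scatter)). The estimated value for compound 4 is 10.5 nM (expected range 5 nM to 21 nM).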

Compound 4, half-maximal inhibitory concentration: 17.7 nM
For compound 4 the middle estimate is 1.7-fold (0.23 log units) below the measured one; measured number inside the range.
By their numbers in this assay, from the lowest: compounds 3, 2, 4 and 1 (each within the scatter of the next, the first and the last beyond it).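

In this assay, the exchange of pyrazin-2-yl for pyrimidin-2-yl on an amine nitrogen in a ring now has a direct reading (a 1.9-fold higher number from compound 3 to compound 4 (0.27 log units; within the scatter)), and at this position the two groups are not told apart on the compounds carrying 1,1-dimethylpropyl. With pyrimidin-2-yl held in place, methyl in place of hydrogen on the saturated chain carbon (a 1.6-fold higher number from compound 2 to compound 4 (0.19 log units; within the scatter)) and 1,1-dimethylpropyl in place of acetyl (a 1.8-fold lower number from compound 1 to compound 4 (0.25 log units; within the scatter)) also stay within the scatter, unlike tert-butyl in place of acetyl (a 2.8-fold lower number from compound 1 to compound 2 (0.45 log units; beyond the scatter)). Nothing measured here bears on what lies behind these numbers.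

From the compounds shown here alone, whether this tolerance extends to a phenyl or pyridin-2-yl on the same ring nitrogen remains open. Also open, going by these compounds, is whether pyrazin-2-yl and pyrimidin-2-yl stay indistinguishable with acetyl or tert-butyl on the aromatic carbon.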